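Acetyl for butyl on the core of compound 1

The source may hold more compounds than are shown below. What is called first, only, known or untested is meant among the compounds shown, and "the series" means these compounds.

Measured so far in an assay on isolated protein for binding affinity to leukotriene B4 receptor 1 (Homo sapiens), tested at 1 uM; on this read-out higher numbers stand for more inhibition at the one concentration tested (going by the name of the read-out) and lower numbers for less inhibition:
compound 1, `CCCCc1cc(C(C)=O)c(O)cc1OCCCCC#N`, 13%
compound 2, `CCc1cc(C(C)=O)c(O)cc1OCCCCCCC#N`, 73%
compound 3, `CC(=O)c1cc(CO)c(OCCCCCCC#N)cc1O`, 8%

Compound 1 sits with compound 3 within the usual scatter, and well below compound 2, which gives a number beyond the scatter higher. Within the data shown here, the only step among measured compounds that differ in one place is a number 65 percentage points lower from compound 2 to compound 3 (beyond the scatter), so a single change at the core can move this read-out a long way downward.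

Compound 4, `CC(=O)c1cc(C(C)=O)c(OCCCCC#N)cc1O`, has not been measured. It differs from compound 1 by acetyl in place of butyl on an aromatic carbon. Among the measured compounds shown here, no measured pair shows an acetyl taking the place of a butyl, so the step from compound 2 to compound 3 bears on it only by showing how far one change can reach; it does not tell the direction for compound 4. Compound 1 already gives a low number, so the room downward is small, while a rise of the size seen between compound 2 and compound 3 cannot be ruled out. The expected step is a number 2 percentage points higher from compound 1 to compound 4 (within the scatter), that is, none beyond the scatter. For compound 4 the estimated value in this assay is 15%, with a range from 0% to 45%.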

Compound 4, a percentage reported as inhibition, at one concentration (the size of the read-out at that concentration, not a potency): 0%
For compound 4 the middle estimate is 15 percentage points above the measured one; measured number inside the range.
By their numbers in this assay, from the lowest: compounds 4, 3 and 1 (each within the scatter of the next, the first and the last beyond it); then compound 2.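

In this assay the position ortho to a 4-cyanobutoxy group and para to a hydroxy group proves sensitive even on a core that already gives a low number: acetyl in place of butyl gives a number 13 percentage points lower from compound 1 to compound 4 (beyond the scatter) as a modest step. With a number 65 percentage points lower from compound 2 to compound 3 (beyond the scatter) on the longer nitrile chain, there are now two single changes at this position, and both go downward, although the step from the low start of compound 1 is much smaller and says little about how far acetyl would reach from a higher start. No measurement on hand accounts for either step.

Still open, from the compounds shown here alone, is whether acetyl on the longer nitrile chain of compound 2 would cost as much as the hydroxy-bearing change did, since the ethyl and butyl compounds differ in more than one place and the roles of the two chains cannot be separated. Also open, going by these compounds, is how this position responds to an amine, a carboxylic acid or a longer alkyl chain than butyl, and whether any such group can raise the number on the shared core.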